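Shorter Alkyl Arms on a Shared Core

The source may report more compounds than this note shows. Statements on the series, on what has been measured and on what is new or still open speak of the compounds shown alone.

Four compounds share one core, a two-ring aromatic system carrying an anilino group, and differ in the dialkylamino group and in the substituent on the carbon-only ring. Compound 1 `CCCN(CCC)c1c(Cl)cc(Cl)c2nc(Nc3c(C)cc(Cl)cc3OC)n(C)c12` carries a dipropylamino group and two chlorine atoms; in an assay on CHO cells for displacement of a labelled ligand from corticotropin-releasing factor receptor 1 (Homo sapiens), read by scintillation counting, with a stated time of 1.5 h (a lower number here means a stronger inhibitor, a higher number a weaker inhibitor), compound 1 gives 170 nM. Compound 2 `CCN(CC)c1ccc(-c2ccccc2)c2nc(Nc3c(C)cc(Cl)cc3OC)n(C)c12` carries a diethylamino group and a phenyl ring. Compound 2 reaches only the assay limit of > 10000 nM, which is a limit and not a number (the limit of > 10000 nM in this assay, at which 1 of the 3 values shown sits). Compound 3 `CCCN(CCC)c1ccc(C#N)c2nc(Nc3c(C)cc(Cl)cc3OC)n(C)c12` carries a dipropylamino group and a nitrile; in this assay compound 3 gives 14 nM, the lowest of the two numbers, and its gap to compound 1 lies beyond the usual scatter. Compound 4 `CCN(CC)c1ccc(C#N)c2nc(Nc3c(C)cc(Cl)cc3OC)n(C)c12` differs from compound 3 in one place: diethylamino in place of dipropylamino on an aromatic carbon. For the measured compounds named here, no measured pair isolates this change. The step is expected to be small, a modest weakening, and is estimated as a 2.1-fold higher number from compound 3 to compound 4 (0.33 log units; beyond the scatter). For compound 4 in this assay a value of 30 nM is expected, within a range of 10 nM to 100 nM.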

Compound 4, half-maximal inhibitory concentration: 13 nM
Estimate against measurement, compound 4: 2.3-fold (0.36 log units) above; low and high end bracket the measured number.
By their numbers in this assay, from the lowest: compounds 4 and 3 (each within the scatter of the next); then compound 1. At a limit, above all of these: compound 2.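

Swapping dipropylamino for diethylamino on this aromatic carbon, para to a cyano group, gives a 1.1-fold lower number from compound 3 to compound 4 (0.03 log units; within the scatter) in this assay, so with the nitrile in place the shorter arms leave the number unchanged within the scatter. With diethylamino held fixed, the substituent on the other carbon makes a far larger difference, with an at least 760-fold lower number from compound 2 to compound 4 (2.88 log units; beyond the scatter) for cyano in place of phenyl, so diethylamino alone does not account for the poor result of compound 2. The figure for compound 2 is a limit of the assay and not a number: the limit of > 10000 nM in this assay, at which 1 of the 4 values shown sits.

Still open, from the compounds shown here alone, is how far the arms can shrink or change shape, as with dimethylamino or a ring amine such as pyrrolidine. Going by these compounds, it is also open whether a small group such as methoxy or a carboxylic acid could stand in for the nitrile, and whether the same swap of arms would stay as flat with such a group.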